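Naphthalenyl in Place of Trichlorophenyl on the Sulfonamide

The source may hold more compounds than are shown below. What is called first, only, known or untested is meant among the compounds shown, and "the series" means these compounds.

Measured so far:
Compound 1, `COc1ccc(S(=O)(=O)NC2=NCCN2C(=S)SN2CCn3c2nsc3=S)cc1OC`
Compound 2, `O=S(=O)(NC1=NCCN1C(=S)SN1CCn2c1nsc2=S)c1ccc(Cl)c(Cl)c1Cl`

In a functional assay on KYSE-510 cells (Homo sapiens) for antiproliferative activity, read by crystal violet staining, with a stated time of 96 h (a lower number here means a stronger inhibitor of growth, a higher number a weaker inhibitor of growth), compound 1 gives only a limit, >= 20000 nM. In this assay compound 2 likewise gives only a limit, >= 20000 nM. Among the compounds with values here, the one measured step, a step that the two limits leave unreadable from compound 1 to compound 2, has no readable size because of the limit of >= 20000 nM in this assay, at which 2 of the 2 values shown sit.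

The next compound, compound 3, is `O=S(=O)(NC1=NCCN1C(=S)SN1CCn2c1nsc2=S)c1ccc2ccccc2c1`. Its change from compound 2 is naphthalen-2-yl in place of 2,3,4-trichlorophenyl on a sulfonyl sulfur. Within the data shown here, no measured step gives a readable size that bears on this change, so no direction beyond the scatter can be expected. Compound 3 is therefore estimated near 20000 nM, within 6000 nM to 40000 nM, an expected step of a number no higher from compound 2 to compound 3 (the limit leaves the size open).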

Compound 3, concentration for 50% growth inhibition: >= 20000 nM
Compound 3 gave a limit, no number (the forecaster's own chance of this, stated with the estimate: 70%); the middle value lies on the limit itself.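

In this assay, within the data shown here, no step among compound 1, compound 2 and compound 3 can be read, because all three give only limits: the limit of >= 20000 nM in this assay, at which 3 of the 3 values shown sit. As far as these compounds go, how strongly each compound inhibits growth, and how the groups on the sulfonyl sulfur compare, stays open.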